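Series notes: from compound 3 to compound 4

This account rests on a few compounds, and the source may have more. Where it says the series, first, only, none or still open, it means among the compounds named here.

In a functional assay on DU-145 cells (Homo sapiens) for cytotoxicity, read by trypan blue exclusion, with a stated time of 96 h (on this read-out higher numbers stand for weaker inhibition and lower numbers for stronger inhibition), compound 3 `COC(=O)C(C)Nc1cc(NS(=O)(=O)/C=C/c2c(OC)cc(OC)cc2OC)ccc1OC` gives 100 nM. Compound 2 `COc1ccc(NS(=O)(=O)/C=C/c2c(OC)cc(OC)cc2OC)cc1` gives 200 nM in this assay, and compound 1 `COc1ccc(/C=C/S(=O)(=O)Nc2ccc(OC)c(F)c2)cc1` gives 5000 nM. Compound 3 therefore carries the lowest of the three numbers; its gap to compound 2 lies within the scatter, while its gap to compound 1 lies beyond it, so compound 3 and compound 2 cannot be ranked against each other on these data.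

Compound 4 `COc1cc(OC)c(/C=C/S(=O)(=O)Nc2ccc(OC)c(NC(C(=O)O)c3ccccc3)c2)c(OC)c1` differs from compound 3 in one place: carboxy(phenyl)methyl in place of 1-(methoxycarbonyl)ethyl on a nitrogen on an aromatic ring.

Among the compounds with values here, only one measured step touches this nitrogen, a 2.0-fold lower number from compound 2 to compound 3 (0.30 log units; within the scatter), and it concerns putting such a group onto the nitrogen at all, not exchanging one group for another. Within the data shown here, no measured pair swaps 1-(methoxycarbonyl)ethyl for carboxy(phenyl)methyl, so nothing in hand points in either direction. The working expectation is accordingly a step no larger than the scatter, the step from compound 3 to compound 4 being estimated as a 1.5-fold higher number from compound 3 to compound 4 (0.18 log units; within the scatter). Compound 4 is thus expected near 150 nM, within a range of 40 nM to 600 nM.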

Compound 4, half-maximal inhibitory concentration: 75 nM
The estimate for compound 4 lay 2.0-fold (0.30 log units) above the measured number; the range from low to high includes it.
By their numbers in this assay, from the lowest: compounds 4, 3 and 2 (each within the scatter of the next, the first and the last beyond it); then compound 1.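

Exchanging 1-(methoxycarbonyl)ethyl for carboxy(phenyl)methyl on this nitrogen brings in a six-membered aromatic ring and a hydrogen-bond donor, yet this assay shows only a 1.3-fold lower number from compound 3 to compound 4 (0.12 log units; within the scatter) and gives no ranking of the two groups. Against the unsubstituted parent, the (carboxy(phenyl)methyl)amino group gives a 2.7-fold lower number from compound 2 to compound 4 (0.43 log units; beyond the scatter), a modest step and the first at this position to clear the scatter, whereas the (1-(methoxycarbonyl)ethyl)amino group gave a 2.0-fold lower number from compound 2 to compound 3 (0.30 log units; within the scatter). No measured evidence accounts for either step.

The exchange alters the ester and the side chain at once, so 1-carboxyethyl and (methoxycarbonyl)(phenyl)methyl on this nitrogen would be needed to separate the two changes. As far as these compounds go, whether the carboxylic acid itself matters remains open, and a primary amide or a longer chain carrying the acid could test this.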